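From Phenylcarbamoyl to Benzoyl in a Dioxygenase Inhibitor Series

The compounds below may be only part of what the source reports. "The series", "measured", "known", "first", "only" and "open" are said of these compounds alone.

Measured compounds:
compound 1, `O=C(/C(=N/O)Nc1ccc(F)c(Br)c1)C1CCN(C(=O)Nc2ccccc2)CC1`: 54 nM
compound 2, `Cn1cc(-c2ccc(NC(=O)N3CCC(C(=O)/C(=N/O)Nc4ccc(F)c(Br)c4)CC3)cc2)cn1`: 15 nM

In an assay on tissue (HeLa cells) for inhibition of Indoleamine 2,3-dioxygenase 1 (Homo sapiens), with a stated time of 48 h (on this read-out lower numbers stand for stronger inhibition and higher numbers for weaker inhibition), compound 1 gives 54 nM, the higher of the two numbers. Going by the values given here, the single measured step, a 3.6-fold lower number from compound 1 to compound 2 (0.56 log units; beyond the scatter), changes the aromatic ring at the far end of the urea. Compound 3, `O=C(/C(=N/O)Nc1ccc(F)c(Br)c1)C1CCN(C(=O)c2ccccc2)CC1`, differs from compound 1 elsewhere: phenyl in place of anilino on a carbonyl carbon, so that phenylcarbamoyl becomes benzoyl and one hydrogen-bond donor is lost. Among the compounds with values here, no measured step touches this carbonyl, and the step from compound 1 to compound 2 says nothing about it. Compound 3 is therefore expected to sit near compound 1, with a small weakening allowed for, an expected step of a 1.9-fold higher number from compound 1 to compound 3 (0.27 log units; within the scatter). The estimate for compound 3 in this assay is 100 nM, with a range from 30 nM to 350 nM.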

Compound 3, half-maximal inhibitory concentration: 281 nM
For compound 3 the middle estimate is 2.8-fold (0.45 log units) below the measured one; the measured number falls inside the stated range.
By their numbers in this assay, from the lowest: compound 2; then compound 1; then compound 3.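

The step shows that the group on this carbonyl carbon, whose other neighbour is the amide-type nitrogen in a ring, matters in this assay: phenyl in place of anilino gives a 5.2-fold higher number from compound 1 to compound 3 (0.72 log units; beyond the scatter). Going by these compounds alone, until now, the only measured change lay on the far aromatic ring, whereas this one keeps that ring unsubstituted and takes out only the anilino nitrogen, with its hydrogen-bond donor. Nothing at hand explains why the number rises with this change.

The compounds shown leave open how a methylamino or a benzyl group on the same carbonyl carbon would compare with anilino and phenyl. From the compounds shown here alone, it also remains open whether 1-methyl-1H-pyrazol-4-yl would lower the number on the benzoyl of compound 3 as it does on the phenylcarbamoyl of compound 1.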